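Methoxy-to-hydrogen steps in a nitro-bearing series

The source may hold more compounds than are shown below. What is called first, only, known or untested is meant among the compounds shown, and "the series" means these compounds.

Measured compounds:
compound 1 `COc1ccc2nc(-c3ccc(N/C=C\C(=O)c4ccc(OC)c([N+](=O)[O-])c4)cc3)sc2c1` 17600 nM
compound 2 `COc1ccc2nc(-c3ccc(N/C=C\C(=O)c4cc(OC)c(OC)c([N+](=O)[O-])c4)cc3)sc2c1` 16100 nM
compound 3 `COc1cc(C(=O)/C=C\Nc2ccc(-c3nc4cc(OC)c(OC)c(OC)c4s3)cc2)cc([N+](=O)[O-])c1OC` 7800 nM

In a functional assay on HeLa cells (Homo sapiens) for antiproliferative activity, read by sulforhodamine B assay, with a stated time of 48 h (a lower number here means a stronger inhibitor, a higher number a weaker inhibitor), compound 1 gives 17600 nM, compound 2 gives 16100 nM and compound 3 gives 7800 nM. Of compound 2 and compound 3 the values show compound 3 with the lower number; the difference between the two cores is not broken down here.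

Compound 4 `COc1cc(OC)c2sc(-c3ccc(N/C=C\C(=O)c4cc(OC)c(OC)c([N+](=O)[O-])c4)cc3)nc2c1` is not yet measured. It arises from compound 3 by hydrogen in place of methoxy on an aromatic carbon. Among the measured compounds the same kind of change occurs once, from compound 2 to compound 1, (hydrogen in place of methoxy on an aromatic carbon), with the step of a 1.1-fold higher number from compound 2 to compound 1 (0.04 log units; within the scatter). The two sites are not the same: in compound 2 the carbon is "ortho to a methoxy group; meta to a large group; meta to a nitro group", in compound 3 it is "part of a fused or bridged system of two rings; ortho to two methoxy groups; meta to a fused ring; para to a fused ring".

For compound 4 a step of a 1.2-fold higher number from compound 3 to compound 4 (0.06 log units; within the scatter) is expected, resting on a 1.1-fold higher number from compound 2 to compound 1 (0.04 log units; within the scatter) in this assay, which stayed within the scatter. Compound 4 is thus estimated at 9000 nM, between 4000 nM and 20000 nM.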

Compound 4, half-maximal inhibitory concentration: 19000 nM
For compound 4 the middle estimate is 2.1-fold (0.32 log units) below the measured one; low and high end bracket the measured number.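

In this assay, hydrogen in place of methoxy on an aromatic carbon gives a 2.4-fold higher number from compound 3 to compound 4 (0.39 log units; beyond the scatter), a step that on its own lies beyond the scatter. Set beside the earlier step on the other core, the two do not separate: the same change on two cores in this assay, a 1.1-fold higher number (0.04 log units; within the scatter) from compound 2 to compound 1 and a 2.4-fold higher number (0.39 log units; beyond the scatter) from compound 3 to compound 4, 2.2-fold (0.35 log units) apart, within the scatter of two such steps. The data therefore give no sign that the change behaves differently on the two cores, but a single pair per core, at two different sites, does not show that its size carries from one core to another.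

Still open, as far as these compounds go, is how an amine or a longer chain such as ethoxy would read at the carbon carrying this methoxy in compound 3. Also open, from the compounds shown here alone, is whether the step holds on compounds without the nitro group.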